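The source may report more compounds than this note shows. Statements on the series, on what has been measured and on what is new or still open speak of the compounds shown alone.

Compound 3 `CC#C[C@@H](CC(=O)O)c1ccc(OC[C@H]2COc3ccccc3O2)cc1` stands second highest of the three numbers in a functional assay on HEK293 cells for agonist activity at Free fatty acid receptor 1 (Homo sapiens), read by fluorescence and calcium flux, with a stated time of 10 min (a lower number here means a smaller maximal response, a higher number a larger maximal response), where compound 3 gives 70%. Compound 1 `O=C(O)CCc1ccc(OCC2COc3cc(Br)ccc3O2)cc1F` lies nearest: in this assay compound 1 gives 67%, within the scatter of compound 3. Among the measured compounds shown here, compound 2 `CC#C[C@@H](CC(=O)O)c1ccc(OC[C@H]2COc3c(Cl)cccc3O2)cc1` differs from compound 3 only in chloro on an aromatic carbon; in this assay compound 2 gives 81%, and the step of a number 11 percentage points lower from compound 2 to compound 3 (beyond the scatter) is the only measured single change. Compound 4 `CC#C[C@@H](CC(=O)O)c1ccc(OC[C@H]2COc3ccc(C(=O)N(C)C)cc3O2)cc1` carries dimethylcarbamoyl in place of hydrogen on an aromatic carbon. The measured step concerns a different substitution on the same fused ring and gives no direct guide to dimethylcarbamoyl; it shows only that one substituent on that ring moved the response modestly. A small step in this assay is therefore expected, a number 5 percentage points higher from compound 3 to compound 4 (within the scatter), the direction uncertain. Compound 4 is estimated at 75%, range 58% to 90%.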

Compound 4, largest response reached (Emax), in percent of the reference or control that the assay uses: 32%
Compound 4: middle estimate off by 43 percentage points, on the high side, outside the stated range (below it).
By their numbers in this assay, from the lowest: compound 4; then compounds 1 and 3 (each within the scatter of the next); then compound 2.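

In this assay, among the compounds shown here, dimethylcarbamoyl in place of hydrogen on an aromatic carbon of the fused system gives a number 38 percentage points lower from compound 3 to compound 4 (beyond the scatter), a large step, whereas the only earlier single change on that ring system, a number 11 percentage points lower from compound 2 to compound 3 (beyond the scatter), was modest. This ring system therefore does not accept every substituent with the maximal response kept. Nothing available accounts for this drop. On these data alone, whether the loss belongs to the carbonyl, the two methyl groups on nitrogen or this particular carbon remains open. A primary carboxamide, a methoxy group or a carboxylic acid on the same carbon would help separate these.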